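Thiazolidine propiolamides: from pentyl to 4-fluorophenyl

The source may report more compounds than this note shows. Statements on the series, on what has been measured and on what is new or still open speak of the compounds shown alone.

Compounds measured so far:
compound 1, `C#CC(=O)N1C(C(C)CCC)SC[C@@H]1C(=O)OCC`, 600 nM
compound 2, `C#CC(=O)N1C(CCCCC)SC[C@@H]1C(=O)OCC`, 1800 nM

Of the compounds shown here, two of a shared core have been measured in a functional assay on Huh-7 cells (Homo sapiens) for inhibition, read by sulforhodamine B assay; on this read-out lower numbers stand for stronger inhibition and higher numbers for weaker inhibition. Compound 1 `C#CC(=O)N1C(C(C)CCC)SC[C@@H]1C(=O)OCC` gives 600 nM. Among the measured compounds shown here, compound 2 `C#CC(=O)N1C(CCCCC)SC[C@@H]1C(=O)OCC` gives 1800 nM, the higher of the two numbers, so the weaker inhibitor in this assay; the only step known, a 3.0-fold higher number from compound 1 to compound 2 (0.48 log units; beyond the scatter), is a modest one and lies beyond the scatter.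

Compound 3 `C#CC(=O)N1C(c2ccc(F)cc2)SC[C@@H]1C(=O)OCC` is not yet measured. It differs from compound 2 by 4-fluorophenyl in place of pentyl on a saturated ring carbon. For the measured compounds named here, no measured step concerns an aromatic group at this place: the one step known, a 3.0-fold higher number from compound 1 to compound 2 (0.48 log units; beyond the scatter), exchanges one saturated chain for another and says nothing about an aryl ring. The expectation for compound 3 therefore rests on weak ground. The writer expects compound 3 to show no step beyond the scatter relative to compound 2, with a 1.5-fold lower number from compound 2 to compound 3 (0.18 log units; within the scatter) as a placeholder, and estimates for compound 3 in this assay 1200 nM, within the range 300 nM to 5000 nM, a wide range owing to the absence of any comparable step.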

Compound 3, half-maximal inhibitory concentration: 700 nM
Estimate against measurement, compound 3: 1.7-fold (0.23 log units) above; the range from low to high includes it.
By their numbers in this assay, from the lowest: compounds 1 and 3 (each within the scatter of the next); then compound 2.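

In this assay, the saturated ring carbon next to the ring nitrogen and next to the ring sulfur turns out to tolerate an aromatic ring as well as a saturated chain: putting 4-fluorophenyl in place of pentyl gives a 2.6-fold lower number from compound 2 to compound 3 (0.41 log units; beyond the scatter) and so recovers what the pentyl compound had lost against the branched chain. Set against 1-methylbutyl, the same aryl group gives a 1.2-fold higher number from compound 1 to compound 3 (0.07 log units; within the scatter) and cannot be told apart from it in this read-out, which leaves compound 2, with steps to both others beyond the scatter, as the weakest of the three and pentyl as the one group here that stands apart. Nothing at hand explains why the two very different groups match or why pentyl falls short.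

The compounds shown leave open whether the fluorine matters at all, a question that plain phenyl or 4-methoxyphenyl at this carbon would address, and whether a pyridine ring or a chain ending in an amine would be tolerated here too. They also leave open whether this ranking of groups would hold if a carboxylic acid replaced the ethyl ester.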